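The source may hold more compounds than are shown below. What is called first, only, known or untested is meant among the compounds shown, and "the series" means these compounds.

Working notes on the aryl vinyl sulfide series, growth inhibition of DU-145 cells.

Compound 1 `O=C(/C(=C\c1ccc(Cl)cc1)Sc1ccc(Cl)cc1)c1ccc(Cl)cc1` is the reference point of the set. In a functional assay on DU-145 cells (Homo sapiens) for inhibition, read by trypan blue exclusion, with a stated time of 96 h (a lower number here means a stronger inhibitor of growth, a higher number a weaker inhibitor of growth), compound 1 gives 1000 nM, the lowest of the two numbers available. Compound 3 `Cc1ccc(S(=O)(=O)/C(=C/c2ccc(O)c([N+](=O)[O-])c2)C(=O)c2ccc(Cl)cc2)cc1` carries a sulfonyl link and a hydroxy-nitrophenyl arm; in this assay compound 3 gives 25000 nM, a gap from compound 1 that lies beyond the scatter. Among the measured compounds shown here, compound 2 `CN(C)c1ccc(/C=C(/SCc2ccc(Cl)cc2)C(=O)c2ccc([N+](=O)[O-])cc2)cc1` reaches only a limit of this assay, > 100000 nM, so no number can be set for it; it is the one value sitting at the limit of > 100000 nM in this assay, at which 1 of the 3 values shown sits.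

Compound 4 `Cc1ccc(CS/C(=C/c2ccc(Cl)cc2)C(=O)c2ccc(Cl)cc2)cc1` is not yet measured. It differs from compound 1 in one place: 4-methylbenzyl in place of 4-chlorophenyl on a sulfur. Compound 2 also carries a benzyl sulfide, though with several other changes as well, so it cannot be read as a step on its own. The step from compound 1 to compound 4 in this assay is expected to be a loss of moderate size, a 3.0-fold higher number from compound 1 to compound 4 (0.48 log units; beyond the scatter). Compound 4 is estimated to give 3000 nM, between 800 nM and 15000 nM.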

Compound 4, concentration for 50% growth inhibition: 10000 nM
For compound 4 the middle estimate is 3.3-fold (0.52 log units) below the measured one, within the range that was stated.
By their numbers in this assay, from the lowest: compound 1; then compound 4; then compound 3. At a limit, above all of these: compound 2.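

The sulfur substituent can now be read on its own: in this assay, 4-methylbenzyl in place of 4-chlorophenyl gives a 10-fold higher number from compound 1 to compound 4 (1.00 log units; beyond the scatter). The earlier compounds shown here differed from one another in several places, so none of them could isolate this position, and this single change is enough to shift growth inhibition measurably. Compound 4 still gives a measured value of 10000 nM, and no measured property shown here bears on the cause of the step.

The change alters both the link to the ring and the ring substituent, and the compounds shown do not separate the two. A 4-methylphenyl group on the sulfur would divide these effects, while an amine-bearing chain at this place remains an open question.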